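Swapping a benzyl group for a small sulfonyl group

The source may hold more compounds than are shown below. What is called first, only, known or untested is meant among the compounds shown, and "the series" means these compounds.

Compound 1 `COc1cc(-c2nc3ccccc3c(=O)[nH]2)ccc1OCc1ccc(Cl)cc1Cl` belongs to a small set of three compounds sharing one core, each measured in an ADME assay on cell membranes (microsomes) for inhibition of cytochrome P450 1A1 (Homo sapiens), read by fluorescence, tested at 10 uM; a higher number here means more inhibition at the concentration tested (going by the name of the read-out), a lower number less inhibition. In that assay compound 1 gives 21.1%, the second highest of the three numbers: compound 2 `O=c1[nH]c(-c2ccc(OS(=O)(=O)c3ccccc3)cc2)nc2ccccc12` gives 0.6%, well below it, and compound 3 `COc1ccc(-c2nc3ccccc3c(=O)[nH]2)cc1OCc1ccc(F)cc1F` gives 44.6%, well above it. Compound 4 `COc1cc(-c2nc3ccccc3c(=O)[nH]2)ccc1OS(C)(=O)=O` has not yet been measured; it differs from compound 1 in one place: methylsulfonyl in place of 2,4-dichlorobenzyl on an oxygen on an aromatic ring. Among the compounds with values here, no pair of measured compounds differs in exactly one place, so no measured step guides the expectation directly. Because compound 2, which also carries a sulfonyl group on that oxygen, gives 0.6%, a step downward from compound 1 to compound 4 of about a number 15.1 percentage points lower from compound 1 to compound 4 (beyond the scatter) is expected. Compound 4 is therefore estimated at 6%, with a range from 0% to 20%.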

Compound 4, a percentage reported as inhibition, at one concentration (the size of the read-out at that concentration, not a potency): 32.6%
Beside the measured number, compound 4's estimate is 26.6 percentage points below it, and the stated range ends below it.
By their numbers in this assay, from the lowest: compound 2; then compound 1; then compound 4; then compound 3.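

In this assay, methylsulfonyl in place of 2,4-dichlorobenzyl on this oxygen gives a number 11.5 percentage points higher from compound 1 to compound 4 (beyond the scatter). At this position, then, the aromatic ring of the benzyl group is not needed for inhibition at the concentration tested, and a sulfonyl group with no ring can take its place without a loss. Nothing available explains the direction of this step. On these data alone, it remains open whether the gain comes from losing the 2,4-dichlorobenzyl or from gaining the sulfonyl, and how a simple acetyl group or a longer alkylsulfonyl chain on the same oxygen would compare.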